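The source may hold more compounds than are shown below. What is called first, only, known or untested is meant among the compounds shown, and "the series" means these compounds.

In a functional assay on CHO-K1 cells for agonist activity at Glucose-dependent insulinotropic receptor (Homo sapiens), read by a luciferase reporter, with a stated time of 5 h (on this read-out higher numbers stand for an effect only at larger amounts of compound and lower numbers for an effect already at smaller amounts), two close relatives set the scene. Compound 1, `CC(C)OC(=O)N1CCC(Oc2cccc3c2CCN3c2ccc(S(C)(=O)=O)cc2)CC1`, gives 501 nM, and compound 2, `CC(C)(C)OC(=O)N1CCC(Oc2cccc3c2CCN3c2ccc(S(C)(=O)=O)cc2)CC1`, gives 158 nM. The one difference between them is methyl in place of hydrogen on a saturated chain carbon bound to an oxygen next to a carbonyl group and two saturated chain carbons, and that single added carbon brings a 3.2-fold lower number from compound 1 to compound 2 (0.50 log units; beyond the scatter).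

Compound 3, `CSC(=O)N1CCC(Oc2ncnc3c2CCN3c2ccc(S(C)(=O)=O)cc2F)CC1`, is built on a different core, and the difference between its core and that of compound 1 is not broken down here. In this assay compound 3 gives 251 nM, a number that sits within the usual scatter of both compound 2 and compound 1, so no order among the three can be read from these values alone.

Compound 4, `CCSC(=O)N1CCC(Oc2ncnc3c2CCN3c2ccc(S(C)(=O)=O)cc2F)CC1`, has not yet been measured. It differs from compound 3 by methyl in place of hydrogen on a saturated chain carbon bound to a sulfur. Within the data shown here, this is the same kind of change as the one from compound 1 to compound 2, an extra methyl on a saturated chain carbon, but not the same change: there the carbon was bound to an oxygen next to a carbonyl group and two saturated chain carbons, here it is bound to a sulfur. Among the measured compounds shown here, with only one earlier example, and that one in different surroundings, the expected step is kept smaller than the measured one. The estimate for compound 4 is a 1.6-fold lower number from compound 3 to compound 4 (0.20 log units; within the scatter), resting on the step of a 3.2-fold lower number from compound 1 to compound 2 (0.50 log units; beyond the scatter) seen before, which would put compound 4 at about 160 nM, with a plausible range from 60 nM to 400 nM.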

Compound 4, half-maximal effective concentration: 31.6 nM
Estimate against measurement, compound 4: 5.1-fold (0.70 log units) above; measured number below the stated range.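

In this assay, turning methylsulfanyl into ethylsulfanyl adds a single carbon and gives a 7.9-fold lower number from compound 3 to compound 4 (0.90 log units; beyond the scatter). This is a larger step than the estimate allowed, yet set beside the earlier example, the extra methyl lowers the number on both cores, and the two step sizes cannot be told apart: the same change on two cores in this assay, a 3.2-fold lower number (0.50 log units; beyond the scatter) from compound 1 to compound 2 and a 7.9-fold lower number (0.90 log units; beyond the scatter) from compound 3 to compound 4, 2.5-fold (0.40 log units) apart, within the scatter of two such steps So in these two pairs, the direction of the change carried over from one core to the other, but two pairs are too few to establish a rule, and they do not show that the step would keep its direction or size on a further core, nor do they explain why the number falls.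

The compounds shown leave open whether a longer chain, such as propyl, or a ring, such as cyclopropyl, on the sulfur would lower the number further or raise it again. They also leave open how a sulfur link compares with an oxygen link on one and the same core, and whether an amine nitrogen in that place would fit this trend.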